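Trimming an oxolane to a methyl: expected clearance

The source may report more compounds than this note shows. Statements on the series, on what has been measured and on what is new or still open speak of the compounds shown alone.

Three compounds share one core and differ only in the group carried on a saturated chain carbon bound to an aromatic carbon. In an ADME assay on microsomes from liver (Homo sapiens) for metabolic stability, read by LC-MS, using NADPH, with stated times of 10 min and 45 min, tested at 1 uM (a higher number here means faster removal of the compound, a lower number slower removal), compound 1 `COC(c1cc(Cl)c2c(c1Cl)C(=O)N(Cc1c(C)cc(C)[nH]c1=O)CC2)C1CCOCC1` gives 130 uL/min; 129 uL/min (2 entries). Compound 3 `Cc1cc(C)c(CN2CCc3c(Cl)cc(C(CO)C4CCOC4)c(Cl)c3C2=O)c(=O)[nH]1` gives 20 uL/min; 25.9 uL/min (2 entries) in this assay. Compound 2 `Cc1cc(C)c(CN2CCc3c(Cl)cc([C@@H](CO)[C@H]4CCCO4)c(Cl)c3C2=O)c(=O)[nH]1` gives 43 uL/min in this assay; that is the only figure it has there, two further entries having given no single number. On the numbers shown, compound 2 stands between compound 1 and compound 3, removed more slowly than compound 1 and faster than compound 3.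

Compound 4 `Cc1cc(C)c(CN2CCc3c(Cl)cc([C@H](C)CO)c(Cl)c3C2=O)c(=O)[nH]1` has not yet been measured in this assay. It differs from compound 2 by methyl in place of oxolan-2-yl on a saturated chain carbon bound to an aromatic carbon and a saturated chain carbon. Among the measured compounds shown here, no pair of measured compounds differs in only one place, so no measured step guides this change directly. The expectation is a modest downward step in this assay, that is, somewhat slower removal, of a size that may well stay within the usual scatter. Compound 4 is therefore estimated at 30 uL/min, with a range from 12 uL/min to 75 uL/min. That estimate means an expected step of a 1.4-fold lower number from compound 2 to compound 4 (0.16 log units; within the scatter).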

Compound 4, intrinsic clearance in a liver preparation (reported as CLH), per the amount of preparation that the assay uses: 15.8 uL/min
For compound 4 the middle estimate is 1.9-fold (0.28 log units) above the measured one; measured number inside the range.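

At the saturated chain carbon bound to an aromatic carbon and a saturated chain carbon, the oxolan-2-yl ring is not needed for slow removal in this assay: swapping it for methyl gives a 2.7-fold lower number from compound 2 to compound 4 (0.43 log units; beyond the scatter). This is the first change in one place that can be read among these compounds, and it shows that a much smaller group with no ring and no oxygen at this position goes with a lower number, not a higher one. Repeat entries of another compound in this assay stay close together, which suggests that a step of this size is more than noise in the measurement: the several entries of compound 3 in this assay, 20 uL/min; 25.9 uL/min (2 entries)

The compounds shown leave open whether the lower number is particular to methyl or would also hold for a longer chain such as ethyl, or for a group containing nitrogen such as an amine, at the same place. They also leave open whether the opposite arrangement in space at the defined stereocentre of compound 4 would give a similar number.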